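Cyclohexylcarbamoyl replaces the cyclobutyl thiocarbamate in compound 3

This account rests on a few compounds, and the source may have more. Where it says the series, first, only, none or still open, it means among the compounds named here.

Compound 2 `O[C@@H]1[C@@H](CO/C(S)=N/C2CCC2)OC(n2cnc3c(NC4CCOC4)ncnc32)[C@@H]1O` gives 148 nM in an assay on DDT1 cells (Cricetulus griseus) for binding affinity to adenosine receptor A1 (Homo sapiens), read by radioligand binding (on this read-out higher numbers stand for weaker inhibition and lower numbers for stronger inhibition), and shows the lower of the two numbers measured, though its step of a 1.4-fold lower number from compound 1 to compound 2 (0.15 log units; within the scatter) from compound 1 `O=C(NC1CC1)OC[C@H]1OC(n2cnc3c(NC4CCOC4)ncnc32)[C@H](O)[C@@H]1O`, which gives 209 nM, stays within the scatter. Compound 3 `O=C(NC1CCCCC1)OC[C@H]1OC(n2cnc3c(NC4CCOC4)ncnc32)[C@H](O)[C@@H]1O` carries a group of 9 heavy atoms (7 carbon, 1 nitrogen, 1 oxygen; one six-membered non-aromatic ring of carbon only) in place of a group of 7 heavy atoms (5 carbon, 1 nitrogen, 1 sulfur; one four-membered non-aromatic ring of carbon only), on an oxygen on a saturated carbon. For the measured compounds named here, the only step measured so far, the one from compound 1 to compound 2, changes the number little, and no other measured pair bears on a six-membered ring at this place. Compound 3 is therefore expected to stay close to compound 2, with an estimated step of a 1.4-fold higher number from compound 2 to compound 3 (0.13 log units; within the scatter). The estimate for compound 3 is 200 nM, ranging from 60 nM to 700 nM.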

Compound 3, inhibition constant: 584 nM
For compound 3 the middle estimate is 2.9-fold (0.47 log units) below the measured one; measured number inside the range.
By their numbers in this assay, from the lowest: compounds 2 and 1 (each within the scatter of the next); then compound 3.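

Cyclohexyl in place of cyclopropyl on an amide-type nitrogen brings a 2.8-fold higher number from compound 1 to compound 3 (0.45 log units; beyond the scatter) and shows that the number at this position responds to the group on that nitrogen, which the earlier step within the scatter did not show. The change from the cyclobutyl thiocarbamate brings a 3.9-fold higher number from compound 2 to compound 3 (0.60 log units; beyond the scatter) but alters the ring and the linking atoms together, so neither alone can be credited with it. Nothing at hand explains the higher number with cyclohexyl. The compounds shown leave open how a cyclopentyl or a cyclobutyl on the same carbamate would read, and whether an open butyl chain or a ring carrying an amine would follow cyclohexyl.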